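The source may report more compounds than this note shows. Statements on the series, on what has been measured and on what is new or still open speak of the compounds shown alone.

Two compounds of a shared core, differing only in a group on one aromatic carbon, have been tested in a functional assay on BXPC-3 cells (Homo sapiens) for inhibition, read by MTT assay, with a stated time of 7 days; on this read-out higher numbers stand for weaker inhibition and lower numbers for stronger inhibition. Compound 1, `CCOC(=O)[C@@H]1CCCN(S(=O)(=O)c2ccc(S(=N)(=O)N(CC)CC)cc2)C1`, gives 3600 nM. Compound 2, `CCOC(=O)[C@@H]1CCCN(S(=O)(=O)c2ccc(S(=O)(=O)N(C)C)cc2)C1`, gives 1000 nM. The only measured step is a 3.6-fold lower number from compound 1 to compound 2 (0.56 log units; beyond the scatter), and on the two numbers shown compound 2 stands lowest, with compound 1 as its nearest neighbour.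

Compound 3, `CCOC(=O)[C@@H]1CCCN(S(=O)(=O)c2ccc(S(=O)(=O)N(CC)C(C)C)cc2)C1`, carries ethyl(isopropyl)amino in place of dimethylamino on a sulfonyl sulfur. Going by the values given here, no measured pair isolates this change. The step from compound 1 to compound 2 bears on it only loosely: that step changed the sulfonyl group itself as well as the amine attached to it, so it cannot say how the amine alone matters. With that single, mixed precedent pointing toward the compound with the smaller amine giving the lower number, a modest move upward from compound 2 is expected, though one that may not clear the usual scatter. The expected step is a 1.8-fold higher number from compound 2 to compound 3 (0.26 log units; within the scatter), and compound 3 is estimated at 1800 nM, within a range from 700 nM to 4500 nM.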

Compound 3, half-maximal inhibitory concentration: 1600 nM
The estimate for compound 3 lay 1.1-fold (0.05 log units) above the measured number; the range from low to high includes it.
By their numbers in this assay, from the lowest: compounds 2 and 3 (each within the scatter of the next); then compound 1.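

In this assay, going by these compounds alone, ethyl(isopropyl)amino in place of dimethylamino on a sulfonyl sulfur gives a 1.6-fold higher number from compound 2 to compound 3 (0.20 log units; within the scatter), the first step that isolates the amine alone; it lies within the scatter, so this read-out does not separate an amine of 6 heavy atoms from one of 3. Against compound 1, the same amine swap sits alongside a different picture: a 2.3-fold lower number from compound 1 to compound 3 (0.35 log units; beyond the scatter) is a modest step beyond the scatter, which suggests that a larger amine alone need not carry the number upward and points to the sulfur group of compound 1 as a candidate, although the two compounds also differ in their amines, so this remains a suggestion and not a separated result. No experimental evidence is available to explain either step.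

What the compounds leave open is how a plain sulfonyl sulfur behaves with diethylamino, the amine of compound 1, which would separate the sulfur group from the amine. Also open, as far as these compounds go, is whether a cyclic amine such as morpholine, or an amine keeping a hydrogen on its nitrogen, would stay within the scatter of compound 2.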